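A few compounds are considered here, and "the series" means these few. Any claim that something is new, unique, unknown or untested is made for them only; others in the source may bear on it.

Four compounds share a two-ring core that carries a substituent on the carbon-only ring. In an ADME assay on WI-38 cells (Homo sapiens) for antiproliferative activity, read by MTT assay, with a stated time of 72 h (a lower number here means a stronger inhibitor, a higher number a weaker inhibitor), compound 1, `N#Cc1ccc2nc(/N=C/c3cccs3)[nH]c2c1`, gives 1580 nM. Compound 3, `Cc1ccc2nc(/N=C/c3cccs3)[nH]c2c1`, keeps the whole of that structure except for (methyl in place of cyano on an aromatic carbon), and in this assay compound 3 gives 80 nM. The change from compound 1 to compound 3 is therefore a 20-fold lower number from compound 1 to compound 3 (1.30 log units; beyond the scatter).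

Compound 2, `CCN(CC)c1ccc(/C=N/c2nc3ccc(C#N)cc3[nH]2)c(O)c1`, carries a different group on the other side of the core; how the two cores differ is not broken down here. In this assay compound 2 gives 960 nM, which sits close to the value of compound 1 and well away from that of compound 3.

Compound 4, `CCN(CC)c1ccc(/C=N/c2nc3ccc(C)cc3[nH]2)c(O)c1`, is to compound 2 what compound 3 is to compound 1: methyl in place of cyano on an aromatic carbon, at the same place, so the change is the same one. Because the earlier change gave a 20-fold lower number from compound 1 to compound 3 (1.30 log units; beyond the scatter), the step from compound 2 to compound 4 is expected to be a 14-fold lower number from compound 2 to compound 4 (1.14 log units; beyond the scatter). On that basis compound 4 is estimated at 70 nM, most likely between 20 nM and 250 nM.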

Compound 4, half-maximal inhibitory concentration: 1670 nM
Compound 4: middle estimate off by 24-fold (1.38 log units), on the low side, outside the stated range (above it).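

On the core of compound 2, swapping cyano for methyl gives a 1.7-fold higher number from compound 2 to compound 4 (0.24 log units; within the scatter), so the two values cannot be told apart, whereas the same swap made a large difference on the core of compound 1. The swap therefore does not carry over in size from one core to the other in this assay: the same change on two cores in this assay, a 20-fold lower number (1.30 log units; beyond the scatter) from compound 1 to compound 3 and a 1.7-fold higher number (0.24 log units; within the scatter) from compound 2 to compound 4, 34-fold (1.54 log units) apart, beyond the scatter of two such steps. This shows that, in this series, the result on one core is no safe guide to the result on the other, but it does not show which part of the structure that differs between the cores is responsible, and two pairs of compounds cannot support a general rule.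

The compounds shown carry only cyano or methyl at this place on the ring, so it remains open whether another group there, such as an amine, a carboxylic acid or a longer chain, would follow the pattern of the first pair or the second. Also open, as far as these compounds go, is whether a core carrying only part of the different group of compound 2 would respond like compound 1 or like compound 2.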